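Two Hydrazide Cores and a Swap of Halophenyl Groups

This account rests on a few compounds, and the source may have more. Where it says the series, first, only, none or still open, it means among the compounds named here.

Compound 1 `O=C(NNc1cccc(Cl)c1)c1ccc(NS(=O)(=O)c2cnc(O)nc2O)cc1` was tested in a functional assay on OVCAR-3 cells (Homo sapiens) for antiproliferative activity, read by MTT assay, with a stated time of 24 h (a lower number here means a stronger inhibitor, a higher number a weaker inhibitor), and compound 1 gave 8410 nM. Compound 2 `O=C(NNc1ccccc1F)c1ccc(NS(=O)(=O)c2cnc(O)nc2O)cc1` differs from compound 1 by 2-fluorophenyl in place of 3-chlorophenyl on an amine nitrogen. In this assay compound 2 gave > 20000 nM, which is a limit of the assay and not a number. The step of an at least 2.3-fold higher number from compound 1 to compound 2 (0.37 log units; beyond the scatter) is therefore known only as a lower bound, because the limit of > 20000 nM in this assay, at which 1 of the 3 values shown sits, sets the edge of what the assay reports.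

Compound 3 `O=C(NNc1cccc(Cl)c1)c1cccc(NS(=O)(=O)c2cnc(O)nc2O)c1` carries the same atoms as compound 1 joined differently; the difference between the two cores is not broken down here. In this assay compound 3 gave 8040 nM, a value within the scatter of compound 1.

Compound 4 `O=C(NNc1ccccc1F)c1cccc(NS(=O)(=O)c2cnc(O)nc2O)c1` differs from compound 3 by 2-fluorophenyl in place of 3-chlorophenyl on an amine nitrogen, the same change that separates compound 1 from compound 2, at the same kind of position. The step from compound 3 to compound 4 is expected to be a 2.7-fold higher number from compound 3 to compound 4 (0.44 log units; beyond the scatter), resting on the step of an at least 2.3-fold higher number from compound 1 to compound 2 (0.37 log units; beyond the scatter) seen on the other core. Compound 4 is expected to give about 22000 nM, likely between 11000 nM and 45000 nM, with a fair chance that only a limit is reported.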

Compound 4, half-maximal inhibitory concentration: 17000 nM
For compound 4 the middle estimate is 1.3-fold (0.11 log units) above the measured one; low and high end bracket the measured number.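

In this assay, putting 2-fluorophenyl in place of 3-chlorophenyl on an amine nitrogen gives a 2.1-fold higher number from compound 3 to compound 4 (0.33 log units; beyond the scatter), so on this core the change again leads to a weaker inhibitor, as it did on the core of compound 1. Setting the two steps side by side shows how far the comparison can go: the same change on two cores in this assay, an at least 2.3-fold higher number (0.37 log units; beyond the scatter) from compound 1 to compound 2 and a 2.1-fold higher number (0.33 log units; beyond the scatter) from compound 3 to compound 4; the limit leaves it open whether they differ

Going by these compounds, the direction of the change therefore carried over from one core to the other, but it remains unknown whether its size did, and a single change on two cores does not make a rule for other changes.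

The swap alters both the halogen and its place on the ring at once, and the compounds shown do not separate these two differences. They also leave open how an unsubstituted phenyl group, or a phenyl group carrying an amine or a carboxylic acid, would compare on either core.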